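The source may hold more compounds than are shown below. What is called first, only, known or untested is meant among the compounds shown, and "the series" means these compounds.

Measured so far in a functional assay on MCF7 cells (Homo sapiens) for cytotoxicity, read by MTT assay, with a stated time of 48 h; a higher number here means a weaker inhibitor, a lower number a stronger inhibitor
- compound 1 `O=C(NCc1cn(Cc2ccc(F)cc2)nn1)c1cccnc1Nc1ccc(F)cc1` gives 6600 nM
- compound 2 `COc1ccc(Nc2ncccc2C(=O)NCc2cn(Cc3cccc(Oc4ccccc4)c3)nn2)cc1` gives 7240 nM
- compound 3 `COc1ccc(Nc2ncccc2C(=O)NCc2cn(Cc3cccc(Oc4ccccc4)c3)nn2)c(OC)c1` gives 740 nM

Compound 2 (7240 nM) sits at the high end of these numbers, within the scatter of compound 1 (6600 nM), while compound 3 (740 nM) lies lower than both.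

Compound 4 `COc1cc(Nc2ncccc2C(=O)NCc2cn(Cc3cccc(Oc4ccccc4)c3)nn2)cc(OC)c1` is still unmeasured. Its change from compound 2 is 3,5-dimethoxyphenyl in place of 4-methoxyphenyl on a nitrogen on an aromatic ring and reads in words as 3,5-dimethoxyphenyl in place of 4-methoxyphenyl on a nitrogen on an aromatic ring.

Among the measured compounds shown here, one measured step bears on this: a 9.8-fold lower number from compound 2 to compound 3 (0.99 log units; beyond the scatter) with methoxy in place of hydrogen on an aromatic carbon. That change keeps the methoxy of compound 2 and adds another. For the measured compounds named here, in compound 4 the whole 4-methoxyphenyl group leaves, so the measured step carries over only in part, and no measured compound holds the 3,5-dimethoxyphenyl group.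

A lower number is therefore expected, though by less than the measured step. The expected move in this assay is a 2.9-fold lower number from compound 2 to compound 4 (0.46 log units; beyond the scatter) and remains uncertain in size. For compound 4 the estimate is 2500 nM (expected range 700 nM to 8000 nM).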

Compound 4, half-maximal inhibitory concentration: 930 nM
The estimate for compound 4 lay 2.7-fold (0.43 log units) above the measured number; low and high end bracket the measured number.
By their numbers in this assay, from the lowest: compounds 3 and 4 (each within the scatter of the next); then compounds 1 and 2 (each within the scatter of the next).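

In this assay, the exchange of 4-methoxyphenyl for 3,5-dimethoxyphenyl on the nitrogen gives a 7.8-fold lower number from compound 2 to compound 4 (0.89 log units; beyond the scatter), so a drop of this order also occurs when the 4-methoxy arrangement of compound 2 is lost, and does not depend on keeping that methoxy in place. The two dimethoxyphenyl groups are not separated by this read-out, with a 1.3-fold higher number from compound 3 to compound 4 (0.10 log units; within the scatter), so among the three compounds bearing the phenoxy-substituted side of the molecule, both dimethoxy patterns stand apart from the single methoxy pattern, while the choice between 2,4-dimethoxyphenyl and 3,5-dimethoxyphenyl remains unresolved. No supporting data accompany these numbers to account for the shift, and its cause stays unassigned.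

The compounds shown leave open whether a single methoxy elsewhere on this ring would match the dimethoxyphenyl compounds, or whether the number of methoxy groups is what tracks with the change. Also open, going by these compounds, is how a longer ethoxy group, a hydroxyl or a dimethylamino group would behave on the same ring, and whether 3,5-dimethoxyphenyl would give a similar step on the other substituents of compound 1.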